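A few compounds are considered here, and "the series" means these few. Any claim that something is new, unique, unknown or untested is made for them only; others in the source may bear on it.

Compound 1 `Oc1ccc(-c2nc3cc(Cl)c(Cl)cc3[nH]2)cc1`: 18000 nM
Compound 2 `CCC(=O)Nc1ccc(-c2nc3cc(C(F)(F)F)ccc3[nH]2)cc1`: > 100000 nM
Compound 3 `CC(=O)Nc1ccc(-c2nc3cc([N+](=O)[O-])ccc3[nH]2)cc1`: > 100000 nM

All three were tested in an ADME assay on Vero cells (Chlorocebus sabaeus) for cytotoxicity; a lower number here means that less compound is tolerated, a higher number that more compound is tolerated. Going by the values given here, compound 1 is the only one with a real number, 18000 nM. For compound 2 the assay reports only a limit, > 100000 nM. For compound 3 the assay likewise reports only a limit, > 100000 nM. Compound 3 therefore stands at the limit of > 100000 nM in this assay, at which 2 of the 3 values shown sit, and no measured step between any two of these compounds exists to lean on.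

Compound 4 `CC(=O)Nc1ccc(-c2nc3ccccc3[nH]2)cc1` is the unmeasured partner of compound 3: hydrogen in place of nitro on an aromatic carbon. The expected step of a number no higher from compound 3 to compound 4 (the limit leaves the size open) is no change beyond the scatter. Compound 4 is estimated at 100000 nM, within 30000 nM to 300000 nM, with another limit rather than a number the likelier outcome.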

Compound 4, half-maximal cytotoxic concentration: > 100000 nM
Compound 4: a limit, no number (the forecaster's own chance of this, stated with the estimate: 65%); the middle value lies on the limit itself.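

Compound 3 and compound 4 both give only limits in this assay, and the step between them cannot be read: the limit of > 100000 nM in this assay, at which 3 of the 4 values shown sit. As far as these compounds go, the concentration at which either compound harms the cells stays open, as does whether hydrogen in place of nitro changes it.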